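An Ethyl Step From a Compound Known Only by a Limit

The source may hold more compounds than are shown below. What is called first, only, known or untested is meant among the compounds shown, and "the series" means these compounds.

Compound 1 `CN(c1ccncc1)n1cccc1`: > 20 mg/kg (a limit)
Compound 2 `C=CCN(c1ccncc1)n1cccc1`: > 20 mg/kg (a limit)
Compound 3 `CN(c1ccncc1)n1ccc(C=O)c1`: > 20 mg/kg (a limit)

In a functional assay on the whole organism with Mus musculus as the target (a higher number here means that more compound is needed for the effect, a lower number that less compound is needed), compound 1 gives > 20 mg/kg, which is a limit and not a number. Its true position is therefore unknown, and the same holds across the series: the limit of > 20 mg/kg in this assay, at which 3 of the 3 values shown sit.

Compound 4 `CCc1cccn1N(C)c1ccncc1` has not yet been measured. It differs from compound 1 as follows: ethyl in place of hydrogen on an aromatic carbon. The change is ethyl in place of hydrogen on an aromatic carbon, next to the ring nitrogen.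

Among the measured compounds shown here, two measured steps bear on it, though neither has a readable size. Vinyl in place of hydrogen on a saturated chain carbon gives a step that the two limits leave unreadable from compound 1 to compound 2. Formyl in place of hydrogen on an aromatic carbon, the closer match in kind, gives a step that the two limits leave unreadable from compound 1 to compound 3. Neither step supplies a direction or a size for the ethyl change, so no firm shift is expected in this assay, and a further limit is the likeliest report. The expected step, a cautious estimate, is a step that the limit leaves unreadable from compound 1 to compound 4. For compound 4 the expected value is 25 mg/kg, with an estimated range from 10 mg/kg to 60 mg/kg.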

Compound 4, dose for half-maximal effect: > 20 mg/kg
Compound 4 gave a limit, no number; the forecaster's own chance of this, stated with the estimate: 70%; the middle value lies beyond the limit too.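

Compound 4, like compound 1, gives only a limit in this assay, so no step can be read between them, neither its size nor its direction. All the compounds shown sit at the same reading: the limit of > 20 mg/kg in this assay, at which 4 of the 4 values shown sit.

What these compounds leave open is where each truly stands in this assay, and whether ethyl, vinyl or formyl changes the dose needed at all.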